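Sulfonamide nitrogen: benzoyl exchanged for 4-methylphenyl

The source may report more compounds than this note shows. Statements on the series, on what has been measured and on what is new or still open speak of the compounds shown alone.

Two compounds of the series carry a measurement in a functional assay on HEK293 cells for agonist activity at probable G-protein coupled receptor 27 (Homo sapiens), read by a luciferase reporter and beta-arrestin recruitment, with a stated time of 10 min; on this read-out lower numbers stand for an effect already at smaller amounts and higher numbers for an effect only at larger amounts of compound. Compound 1 `O=C(NS(=O)(=O)c1ccc(NC(=O)c2ccc(Cl)cc2Cl)cc1)c1ccccc1` gives in this assay a value of > 100000 nM, which is a limit of the assay and not a number. Compound 2 `O=C(Nc1ccc(Cl)cc1Cl)c1ccc(S(=O)(=O)Nc2ccccc2)cc1` gives in this assay a value of > 100000 nM, again a limit rather than a number. Compound 1 therefore stands where every measured value of the series stands, namely on (the limit of > 100000 nM in this assay, at which 2 of the 2 values shown sit). No step between two measured compounds is shown, so no size of change has been observed so far.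

Compound 3 `Cc1ccc(NS(=O)(=O)c2ccc(NC(=O)c3ccc(Cl)cc3Cl)cc2)cc1` has not been measured. It differs from compound 1 in one place: 4-methylphenyl in place of benzoyl on a sulfonamide nitrogen. Cut one bond further out, the change reads benzamido to (4-methylphenyl)amino.

Going by the values given here, with both known values sitting on the limit and no measured step available, no change beyond the scatter is expected; the step from compound 1 to compound 3 is estimated as a number no higher from compound 1 to compound 3 (the limit leaves the size open). For compound 3 in this assay the expected value is 100000 nM, with a range from 30000 nM to 300000 nM, most probably reported once more as a limit.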

Compound 3, half-maximal effective concentration: > 100000 nM
Compound 3 ended at the assay's limit; the forecaster's own chance of this, stated with the estimate: 80%; the middle value lies on the limit itself.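

Compound 1 and compound 3 both sit on a limit of this assay, not on a number, so no step between them can be read: the limit of > 100000 nM in this assay, at which 3 of the 3 values shown sit.

The compounds shown leave open whether any change to the core of compound 1 gives a measurable effect in this assay, since none has yet given a value that is a number.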